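This account rests on a few compounds, and the source may have more. Where it says the series, first, only, none or still open, it means among the compounds named here.

Three compounds have numbers in a functional assay on BGC-823 cells (Homo sapiens) for antiproliferative activity, read by MTT assay, tested at 5 uM; on this read-out higher numbers stand for a stronger effect at the one concentration tested and lower numbers for a weaker effect. Compound 1 `COc1cc(C(=O)N/N=C/c2ccc(F)c(F)c2)cc(OC)c1OC` gives 51.9%, compound 3 `COc1cc(C(=O)N/N=C/c2c(Cl)cccc2Cl)cc(OC)c1OC` gives 27.8%, and compound 2 `COc1cc(C2=NN(C(C)=O)C(c3ccc(F)cc3)O2)cc(OC)c1OC` gives 13.3%. Compound 2 stands lowest of the three; its gap to compound 3 and its larger gap to compound 1 both lie beyond the usual scatter of repeated measurements. For the measured compounds named here, the only step between compounds that differ in a single place is a number 24.1 percentage points lower from compound 1 to compound 3 (beyond the scatter), a modest fall when the ring on the carbon with a double bond to nitrogen is exchanged.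

Compound 4 `COc1cc(C2=NN(C(C)=O)C(c3cccc(C(F)(F)F)c3)O2)cc(OC)c1OC` has not yet been measured. It differs from compound 2 in one place: 3-(trifluoromethyl)phenyl in place of 4-fluorophenyl on a saturated ring carbon. Going by the values given here, no measured pair exchanges the ring on the saturated ring carbon of the core of compound 2, so the only guidance is the measured step from compound 1 to compound 3, where a ring exchange on a different core moved the number modestly. The step expected in this assay is therefore small and may fall in either direction, possibly within the scatter: a number 2.7 percentage points higher from compound 2 to compound 4 (within the scatter). Compound 4 is estimated at 16%, with a range from 4% to 32%.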

Compound 4, a percentage reported as inhibition, at one concentration (the size of the read-out at that concentration, not a potency): 41.1%
Compound 4: the middle estimate sits 25.1 percentage points below what was measured; measured number outside the range, above it.
By their numbers in this assay, from the lowest: compound 2; then compound 3; then compound 4; then compound 1.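

In this assay, for the compounds shown here, the first measured exchange on the saturated ring carbon of this core, 3-(trifluoromethyl)phenyl in place of 4-fluorophenyl, gives a number 27.8 percentage points higher from compound 2 to compound 4 (beyond the scatter). This shows that the ring on this carbon is not a silent part of the molecule: with the rest of the structure unchanged, the exchange alone moves the number by more than repeat measurements usually differ. The compounds shown offer nothing that explains the rise.

Because the pair changes both the group on the phenyl ring and that group's place on the ring, it cannot tell whether the gain follows the trifluoromethyl group itself or where it sits. From the compounds shown here alone, how a nitrile, an amine or a carboxylic acid on this phenyl ring would read remains open, as does the effect of a longer chain in place of the acetyl group on the neighbouring ring atom.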